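Removing the Isopropyl Group of Compound 3

A few compounds are considered here, and "the series" means these few. Any claim that something is new, unique, unknown or untested is made for them only; others in the source may bear on it.

Of the compounds shown here, three have been tested in a functional assay on HeLa cells (Homo sapiens) for inhibition, read by CCK-8 assay, with a stated time of 48 h; on this read-out lower numbers stand for stronger inhibition and higher numbers for weaker inhibition. Compound 1 `O=[N+]([O-])c1ccc(Oc2ccccc2-c2ccc(S(=O)(=O)NCCNC(=S)Nc3cccc(Cl)c3)s2)cc1` gives 4600 nM, and compound 2 `O=C(NCCNS(=O)(=O)c1ccc(-c2ccccc2OCc2ccccc2)s1)Nc1cc(C(F)(F)F)cc(C(F)(F)F)c1` gives 13500 nM. For compound 3 `CC(C)c1ccc(Oc2ccc(O)c(O)c2)c(-c2ccsc2S(=O)(=O)NCCNC(=S)Nc2cc(C(F)(F)F)cc(C(F)(F)F)c2)c1` the assay reports only a limit, > 20000 nM, so compound 3 stands at the limit of > 20000 nM in this assay, at which 1 of the 3 values shown sits, rather than at a measured number. Compound 4 `O=S(=O)(NCCNC(=S)Nc1cc(C(F)(F)F)cc(C(F)(F)F)c1)c1sccc1-c1ccccc1Oc1ccc(O)c(O)c1` differs from compound 3 in one place: hydrogen in place of isopropyl on an aromatic carbon. Going by the values given here, no measured pair shows a change of this kind, so its effect cannot be read from the data; with compound 3 already at the limit, no move beyond the usual scatter is expected in either direction. Compound 4 is therefore expected to give about 20000 nM, between 8000 nM and 50000 nM. The expected step is a number no higher from compound 3 to compound 4 (the limit leaves the size open), essentially none.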

Compound 4, half-maximal inhibitory concentration: > 50000 nM
Compound 4: no number, only a limit; the forecaster's own chance of this, stated with the estimate: 65%; at least 2.5-fold (0.39 log units) between middle value and limit.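

Going by these compounds alone, compound 3 and compound 4 each give only a limit, so no step between them can be read. The compounds shown leave open whether hydrogen in place of isopropyl changes inhibition at all.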